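Bromo on the pendant phenyl of the chalcone-triazole series

The source may hold more compounds than are shown below. What is called first, only, known or untested is meant among the compounds shown, and "the series" means these compounds.

Compound 1 `COc1cc(/C=C/C(=O)c2cccc(-n3cc(-c4ccccc4)nn3)c2)ccc1O` gives 16800 nM in a functional assay on RAW264.7 cells (Mus musculus) for inhibition, with a stated time of 4 days (on this read-out higher numbers stand for weaker inhibition and lower numbers for stronger inhibition), the highest of the three numbers seen so far, though compound 3 sits within the scatter of it. Compound 2 `COc1cc(/C=C/C(=O)c2cccc(-n3cc(-c4ccccc4C(F)(F)F)nn3)c2)ccc1O` gives 5070 nM; compound 3 `COc1cc(/C=C/C(=O)c2cccc(-n3cc(-c4cccc(Cl)c4)nn3)c2)ccc1O` gives 14300 nM. The two measured steps from compound 1 are a 3.3-fold lower number from compound 1 to compound 2 (0.52 log units; beyond the scatter) and a 1.2-fold lower number from compound 1 to compound 3 (0.07 log units; within the scatter). Compound 4 `COc1cc(/C=C/C(=O)c2cccc(-n3cc(-c4ccc(Br)cc4)nn3)c2)ccc1O` differs from compound 1 by bromo in place of hydrogen on an aromatic carbon. The chloro step bears most directly on it and stayed within the scatter; only the trifluoromethyl step moved the number. For compound 4 the expected step is therefore a 1.4-fold lower number from compound 1 to compound 4 (0.15 log units; within the scatter), at most a small lowering. Compound 4 is estimated at 12000 nM, with a range of 6000 nM to 25000 nM in this assay.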

Compound 4, half-maximal inhibitory concentration: 19100 nM
Beside the measured number, compound 4's estimate is 1.6-fold (0.20 log units) below it; the measured number falls inside the stated range.
By their numbers in this assay, from the lowest: compound 2; then compounds 3, 1 and 4 (each within the scatter of the next).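

In this assay, bromo para to a large group on the phenyl leaves the number in place, with a 1.1-fold higher number from compound 1 to compound 4 (0.06 log units; within the scatter) and a 1.3-fold higher number from compound 3 to compound 4 (0.13 log units; within the scatter), so neither chloro nor bromo separates from the unsubstituted phenyl. The 2-(trifluoromethyl)phenyl compound alone stands apart, with a 3.8-fold higher number from compound 2 to compound 4 (0.58 log units; beyond the scatter). Nothing available explains this difference.

Still open, going by these compounds, is whether the lower number of compound 2 follows the trifluoromethyl group or its place on the ring. Also open, on these data alone, is how an amine or a carboxylic acid at the bromo position would read.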